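The compounds below may be only part of what the source reports. "The series", "measured", "known", "first", "only" and "open" are said of these compounds alone.

In an ADME assay on the whole organism (strain Sprague-Dawley) for pharmacokinetics, with Rattus norvegicus as the target, at a dose of 2 mg/kg by the oral route (a higher number here means more compound in the circulation at the dose given, a lower number less compound in the circulation), two compounds sharing one core have been measured. Compound 1 `CC(C)C1(c2ccc(-c3ccc4ccccc4c3)[nH]c2=O)OC(=O)NC1=O` gives 4400 ng.h/mL, while compound 2 `CC(C)C1(c2cc(Cl)c(-c3ccc4ccccc4c3)[nH]c2=O)OC(=O)NC1=O` gives 12900 ng.h/mL, the higher of the two numbers. The unmeasured compound 3 `Cc1cc(C2(C(C)C)OC(=O)NC2=O)c(=O)[nH]c1-c1ccc2ccccc2c1` departs from compound 2 at a single group: methyl in place of chloro on an aromatic carbon. This is methyl in place of chloro on an aromatic carbon, ortho to a large group and two atoms from the ring nitrogen. Among the compounds with values here, the one measured step that bears on this change is a 2.9-fold higher number from compound 1 to compound 2 (0.47 log units; beyond the scatter), a modest step beyond the scatter, made by chloro replacing hydrogen on that same carbon. Within the data shown here, no methyl compound has been measured, so this step offers only indirect guidance. Compound 1, with hydrogen there, stands at 4400 ng.h/mL, so removing the chloro of compound 2 is expected to lower the number, though probably not that far. A small fall is therefore expected, perhaps none beyond the scatter. This amounts to an estimated 1.6-fold lower number from compound 2 to compound 3 (0.21 log units; within the scatter). Compound 3 is estimated at 8000 ng.h/mL, with an expected range of 3500 ng.h/mL to 18000 ng.h/mL.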

Compound 3, area under the concentration-time curve: 13500 ng.h/mL
The estimate for compound 3 lay 1.7-fold (0.23 log units) below the measured number; measured number inside the range.
By their numbers in this assay, from the lowest: compound 1; then compounds 2 and 3 (each within the scatter of the next).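

In this assay, methyl in place of chloro on this aromatic carbon, ortho to a large group and two atoms from the ring nitrogen, gives a step within the scatter (a 1.0-fold higher number from compound 2 to compound 3 (0.02 log units; within the scatter)), so the two groups cannot be told apart at this position. Methyl in place of hydrogen on the same carbon gives a step beyond the scatter (a 3.1-fold higher number from compound 1 to compound 3 (0.49 log units; beyond the scatter)), as did chloro in place of hydrogen (a 2.9-fold higher number from compound 1 to compound 2 (0.47 log units; beyond the scatter)), so the difference from hydrogen in this assay is no longer tied to chloro alone but is seen with both groups tested here. Nothing at hand accounts for why these two groups read alike in this measure or why both differ from hydrogen.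

The compounds shown leave open whether other groups on this carbon, such as fluoro, methoxy, an amine or a longer chain, would read like methyl and chloro or like hydrogen. They also leave open whether the same pattern would hold if the isopropyl group or the naphthyl group of the shared core were replaced by another group.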